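Replacing Trifluoromethyl with Methoxy in Compound 3

A few compounds are considered here, and "the series" means these few. Any claim that something is new, unique, unknown or untested is made for them only; others in the source may bear on it.

In a physicochemical assay for solubility, read by HPLC, in phosphate buffer, measured as kinetic solubility, at pH 7.4 (a higher number here means a more soluble compound, a lower number a less soluble compound), three related compounds have been measured. Compound 1 (`NS(=O)(=O)c1ccc(-c2cc(C(=O)C3CC3)nn2-c2ccc(Cl)cc2)cc1`) gives 25600 nM, and compound 2 (`NS(=O)(=O)c1ccc(-c2cc(C(=O)C3CCC3)nn2-c2ccc(Cl)cc2)cc1`) gives 17200 nM. Compound 3 (`CCC(=O)c1cc(-c2ccc(S(N)(=O)=O)cc2)n(-c2ccc(C(F)(F)F)cc2)n1`) gives 7500 nM, the lowest number of the three, and its gaps to the other two lie beyond the usual scatter of repeated measurements.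

The next compound, compound 4 (`CCC(=O)c1cc(-c2ccc(S(N)(=O)=O)cc2)n(-c2ccc(OC)cc2)n1`), has not yet been measured. It carries methoxy in place of trifluoromethyl on an aromatic carbon.

Going by the values given here, no measured step makes this exact exchange. Among the compounds with values here, the only single-change step available is a 1.5-fold lower number from compound 1 to compound 2 (0.17 log units; within the scatter), which lies within the scatter and concerns a different group, so it gives only a rough sense of how small a change can be. Compound 1 and compound 2 each differ from compound 3 in more than one place, so their values cannot isolate the exchange either. Within the data shown here, with compound 3 at 7500 nM, the lowest number so far, a rise towards the other two seems more likely than a fall, though this is only a weak guide.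

The expected change is a 2.1-fold higher number from compound 3 to compound 4 (0.33 log units; beyond the scatter). For compound 4, the estimated value is 16000 nM, with an expected range from 7000 nM to 36000 nM.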

Compound 4, solubility: 64300 nM
Compound 4: the middle estimate sits 4.0-fold (0.60 log units) below what was measured, and the stated range ends below it.
By their numbers in this assay, from the lowest: compound 3; then compounds 2 and 1 (each within the scatter of the next); then compound 4.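

In this assay, methoxy in place of trifluoromethyl on an aromatic carbon, para to a large group, gives an 8.6-fold higher number from compound 3 to compound 4 (0.93 log units; beyond the scatter). Going by these compounds alone, this shows that a single exchange at this position can move the number well beyond the scatter, which the only earlier single-change step could not show: a 1.5-fold lower number from compound 1 to compound 2 (0.17 log units; within the scatter) stayed within the scatter and concerned cyclobutyl in place of cyclopropyl on a carbonyl carbon. The exchange takes away the fluorine atoms and brings in an oxygen that counts as a hydrogen-bond acceptor, yet nothing measured here ties the rise to that difference or to any other.

This single step cannot say whether another group on the same aromatic carbon, such as an amine, a hydroxyl or the longer ethoxy, would give a rise of similar size, or whether methoxy itself is what matters. It also leaves open whether the same exchange would act in the same way with the cyclopropyl or cyclobutyl on the carbonyl carbon, as in compound 1 and compound 2, where chlorine rather than trifluoromethyl occupies this place.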